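The source may report more compounds than this note shows. Statements on the series, on what has been measured and on what is new or still open speak of the compounds shown alone.

Compound 1 `O=c1ncn(Cc2c(F)cc(F)cc2F)c2ccc(Oc3cccc(-c4nc5ncccc5o4)c3C(F)(F)F)cc12` gives 3 10^-6 cm/s in an ADME assay on Caco-2 cells (Homo sapiens) for permeability, in the apical to basolateral direction; a higher number here means that the compound crosses the layer faster, a lower number that the compound crosses the layer more slowly.
Compound 2 `O=c1ncn(Cc2c(F)cc(F)cc2F)c2ccc(Oc3cccc(-c4ccc5[nH]cnc5c4)c3C(F)(F)F)cc12` gives 0.4 10^-6 cm/s.

Among the measured compounds shown here, compound 1 stands highest of the two numbers, and its only measured neighbour is compound 2, which shows a 7.5-fold lower number from compound 1 to compound 2 (0.88 log units; beyond the scatter). Compound 3 `Nc1ccc(-c2cccc(Oc3ccc4c(c3)c(=O)ncn4Cc3c(F)cc(F)cc3F)c2C(F)(F)F)cn1` carries a different change at the same place: a group of 7 heavy atoms (5 carbon, 2 nitrogen; one six-membered aromatic ring with 1 hetero atom) in place of a group of 9 heavy atoms (6 carbon, 2 nitrogen, 1 oxygen; one five-membered aromatic ring with 2 hetero atoms, one six-membered aromatic ring with 1 hetero atom), on an aromatic carbon. For the measured compounds named here, the one step that bears on it, from compound 1 to compound 2, brought in a hydrogen-bond donor and lowered the number beyond the scatter; the entering 6-aminopyridin-3-yl also brings one donor. A lower number is therefore expected for compound 3, estimated as a 3.0-fold lower number from compound 1 to compound 3 (0.48 log units; beyond the scatter), giving 1 10^-6 cm/s with a range from 0.3 10^-6 cm/s to 3 10^-6 cm/s.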

Compound 3, apparent permeability: 4.1 10^-6 cm/s
Beside the measured number, compound 3's estimate is 4.1-fold (0.61 log units) below it; the measured number lies above the stated range.
By their numbers in this assay, from the lowest: compound 2; then compounds 1 and 3 (each within the scatter of the next).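

In this assay, a hydrogen-bond donor at this position does not by itself bring a low number: 6-aminopyridin-3-yl carries one, yet replacing the fused group gives a 1.4-fold higher number from compound 1 to compound 3 (0.14 log units; within the scatter). Set against 1H-benzimidazol-5-yl, which also carries a donor, 6-aminopyridin-3-yl gives a 10-fold higher number from compound 2 to compound 3 (1.01 log units; beyond the scatter), so the donor alone does not separate compound 2 from compound 3. Nothing shown here accounts for that gap. From the compounds shown here alone, what remains open is whether the amine matters, and what a plain pyridin-3-yl or a carboxylic acid would give at this place.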